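Swapping an aryloxy for a benzylamino group on a shared core

This account rests on a few compounds, and the source may have more. Where it says the series, first, only, none or still open, it means among the compounds named here.

Compound 1 `Nc1cc(N)c2nc(-c3ccccc3)c(Oc3ccc(Cl)c(Cl)c3)nc2c1`: 83200 nM
Compound 2 `COc1cc(CNc2nc3cc(N)cc(N)c3nc2-c2ccccc2)cc(OC)c1OC`: 30200 nM
Compound 3 `CCOC(=O)[C@H](CCC(=O)O)NC(=O)c1ccc(Oc2nc3cc(N)cc(N)c3nc2-c2ccccc2)cc1`: < 100000 nM

In a functional assay on U-251 cells (Homo sapiens) for inhibition, read by sulforhodamine B assay, with a stated time of 48 h (on this read-out lower numbers stand for higher toxicity in this test and higher numbers for lower toxicity in this test), compound 1 gives 83200 nM, the highest of the two numbers recorded; its nearest neighbour is compound 2 with 30200 nM, a gap that lies beyond the usual scatter. For compound 3 the assay reports only a limit, < 100000 nM, and no number (the limit of < 100000 nM in this assay, at which 1 of the 3 values shown sits). Compound 4 `Nc1cc(N)c2nc(-c3ccccc3)c(NCc3ccc(F)cc3)nc2c1` has not been measured in this assay. It differs from compound 1 in one place: (4-fluorobenzyl)amino in place of 3,4-dichlorophenoxy on an aromatic carbon. Within the data shown here, no measured pair isolates this change, so compound 4 is expected to show a step of a 2.1-fold lower number from compound 1 to compound 4 (0.32 log units; beyond the scatter), toward the lower end of the numbers seen. Compound 4 is therefore estimated at 40000 nM, within 15000 nM to 100000 nM.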

Compound 4, concentration lethal to 50% of the cells: 6310 nM
The estimate for compound 4 lay 6.3-fold (0.80 log units) above the measured number, outside the stated range (below it).
By their numbers in this assay, from the lowest: compound 4; then compound 2; then compound 1.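

In this assay, the position next to the ring nitrogen proves sensitive to the group it carries: (4-fluorobenzyl)amino in place of 3,4-dichlorophenoxy gives a 13-fold lower number from compound 1 to compound 4 (1.12 log units; beyond the scatter), a large step. The two groups match in heavy atom count, but the entering group has a hydrogen-bond donor that the leaving group lacks. Nothing measured here bears on the cause of this step.

The compounds shown leave open whether the step belongs to the amine nitrogen or to the ring substituents. They also leave open how a tertiary N-methyl amine or an unsubstituted benzylamino group would read at this position.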